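The source may hold more compounds than are shown below. What is called first, only, known or untested is meant among the compounds shown, and "the series" means these compounds.

Working notes on the series. Of the compounds shown here, two of the shared core have been measured in an ADME assay on MDBK cells (Bos taurus) for cytotoxicity, read by MTT assay, with a stated time of 96 h; a lower number here means that less compound is tolerated, a higher number that more compound is tolerated. Compound 1 `Oc1ccc(-c2nc3cc(C(F)(F)F)ccc3[nH]2)cc1` gives 51000 nM in this assay. Compound 2 `CC(=O)Nc1ccc(-c2nc3cc([N+](=O)[O-])ccc3[nH]2)cc1` is known in this assay only as a limit, > 100000 nM, and not as a number. That is the situation described by the limit of > 100000 nM in this assay, at which 1 of the 2 values shown sits, so compound 2 stands at the tolerated end of the two values shown, with no number of its own to set against compound 1.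

Compound 3 `CC(=O)Nc1ccc(-c2nc3cc(C(F)(F)F)ccc3[nH]2)cc1` has not yet been measured in this assay. It differs from compound 2 in one place: trifluoromethyl in place of nitro on an aromatic carbon. Compound 1 carries the same trifluoromethyl on the same core and gives 51000 nM in this assay, with a hydroxy aryl group in place of the acetamido aryl group of compound 3.

Because compound 2 sits at > 100000 nM, only a downward move from the limit can appear, and the expected step is an at least 1.3-fold lower number from compound 2 to compound 3 (0.12 log units; that floor lies within the scatter), small or within the scatter if compound 3 also reaches the limit. For compound 3 the value expected in this assay is 75000 nM, in the range 30000 nM to 150000 nM.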

Compound 3, half-maximal cytotoxic concentration: 50000 nM
For compound 3 the middle estimate is 1.5-fold (0.18 log units) above the measured one, and the stated range covers the measured number.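

In this assay, trifluoromethyl in place of nitro on an aromatic carbon of the shared core now has a first reading, an at least 2.0-fold lower number from compound 2 to compound 3 (0.30 log units; that floor lies within the scatter). That reading is only a floor and the full size of the step cannot be read, because compound 2 is known only as a limit: the limit of > 100000 nM in this assay, at which 1 of the 3 values shown sits.

The second comparison holds trifluoromethyl fixed and exchanges the group on the other aromatic ring: acetamido in place of hydroxy gives a 1.0-fold lower number from compound 1 to compound 3 (0.01 log units; within the scatter), so this assay does not separate these two groups when trifluoromethyl is present.

The compounds shown leave open whether any group on this aromatic carbon, such as an amine or a carboxylic acid, would give a step beyond the scatter in this assay. They also leave open whether hydroxy and acetamido would still read alike with nitro on the core in place of trifluoromethyl, since the only nitro compound shown carries acetamido.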